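Iodo substitution on the anilino ring of compound 2

A few compounds are considered here, and "the series" means these few. Any claim that something is new, unique, unknown or untested is made for them only; others in the source may bear on it.

The series is followed in an assay on microsomes from intestine for inhibition of acyl-CoA:cholesterol acyltransferase (Oryctolagus cuniculus); on this read-out lower numbers stand for stronger inhibition and higher numbers for weaker inhibition. Compound 1 `CC(C)c1cccc(C(C)C)c1NC(=O)NCCCc1ccccc1` gives 191 nM. For the measured compounds named here, compound 2 `O=C(NCC1(c2ccccc2)CCCCC1)Nc1ccccc1` gives 2300 nM in this assay, the highest of the two numbers so far; compound 1 sits at the lower number, and that gap lies beyond the scatter. Going by the values given here, no step between measured compounds that differ in one place exists in this set, so the effect of iodo on the aromatic ring is not yet known from these data. Compound 3 `O=C(NCC1(c2ccccc2)CCCCC1)Nc1ccc(I)cc1` differs from compound 2 by iodo in place of hydrogen on an aromatic carbon, the change sitting on an aromatic carbon of a six-membered aromatic ring of carbon only, para to a large group. Among the compounds with values here, with no comparable step to rest on, the expectation is a moderate move toward a lower number, a 2.3-fold lower number from compound 2 to compound 3 (0.36 log units; beyond the scatter), though a result within the scatter would not surprise. Compound 3 is therefore expected to give about 1000 nM in this assay, with a range of 300 nM to 4000 nM.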

Compound 3, half-maximal inhibitory concentration: 2300 nM
Compound 3: the middle estimate sits 2.3-fold (0.36 log units) below what was measured; measured number inside the range.
By their numbers in this assay, from the lowest: compound 1; then compounds 2 and 3 (each within the scatter of the next).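

Notes on the anilino ring: in this assay the series now has its first one-place step, and it reads no change at the digits printed from compound 2 to compound 3 (within the scatter) for iodo in place of hydrogen on an aromatic carbon. The change from phenyl to 4-iodophenyl, para to a large group, therefore adds one iodine atom at this position with no read-out shift beyond the scatter. The data offer no measurement that would explain this result.

Still open, as far as these compounds go, is whether this position stays as undemanding with other groups, such as a methoxy group, a carboxylic acid or a dimethylamino group. Also open, from the compounds shown here alone, is whether iodo elsewhere on the same ring, or on the other phenyl ring, would leave the number equally unmoved.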